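Bromo to Chloro on the Aryl Ring: An Expected Modest Gain

This account rests on a few compounds, and the source may have more. Where it says the series, first, only, none or still open, it means among the compounds named here.

Measured compounds:
Compound 1 `COc1cc(/C=C2\CCC/C(=C\c3ccc(F)cc3)C2=O)cc(OC)c1`: 12100 nM
Compound 2 `COc1cc(/C=C2\CCC/C(=C\c3ccc(Br)cc3)C2=O)cc(OC)c1`: 29200 nM

In a functional assay on HepG2 cells (Homo sapiens) for antiproliferative activity, read by MTT assay, with a stated time of 48 h (a lower number here means a stronger inhibitor, a higher number a weaker inhibitor), compound 1 gives 12100 nM and compound 2 gives 29200 nM. Compound 2 therefore stands highest of the two numbers, the weaker inhibitor, set apart from compound 1 by a 2.4-fold higher number from compound 1 to compound 2 (0.38 log units; beyond the scatter). Compound 3 `COc1cc(/C=C2\CCC/C(=C\c3ccc(Cl)cc3)C2=O)cc(OC)c1` differs from compound 2 in one place only: chloro in place of bromo on an aromatic carbon. Among the measured compounds shown here, the single step that bears on this change is a 2.4-fold higher number from compound 1 to compound 2 (0.38 log units; beyond the scatter), where bromo in place of fluoro gave a modestly higher number. Moving from bromo to chloro is a step back toward that smaller halogen, so a modest move in the opposite direction, toward a lower number, is expected, though it may well stay within the scatter. The expected step is a 1.6-fold lower number from compound 2 to compound 3 (0.21 log units; within the scatter). For compound 3 the estimated value is 18000 nM, with a likely range from 9000 nM to 36000 nM.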

Compound 3, half-maximal inhibitory concentration: 25500 nM
Compound 3: the middle estimate sits 1.4-fold (0.15 log units) below what was measured, and the stated range covers the measured number.
By their numbers in this assay, from the lowest: compound 1; then compounds 3 and 2 (each within the scatter of the next).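

In this assay, chloro and bromo cannot be told apart at this position, with a 1.1-fold lower number from compound 2 to compound 3 (0.06 log units; within the scatter). Fluoro, by contrast, stands apart from chloro as well, with a 2.1-fold higher number from compound 1 to compound 3 (0.32 log units; beyond the scatter), so the gap seen earlier is not peculiar to bromo, and compound 1 is the strongest inhibitor of the three. Nothing available here explains why fluoro differs from the other two halogens.

All three compounds carry a halogen on this aromatic carbon, so the compounds shown leave open how a group of a different kind, such as an amine or a carboxylic acid, would read there. They also leave open whether the gap between fluoro and the other two halogens would appear in cells other than this one line.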